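A few compounds are considered here, and "the series" means these few. Any claim that something is new, unique, unknown or untested is made for them only; others in the source may bear on it.

Measured compounds:
compound 1 `CCN(CC)Cc1ccc(S(=O)(=O)NCc2ccc(CNC(=O)c3ccc(F)cc3)cc2)cc1` — 1 nM
compound 2 `O=C(NCc1ccc(CNS(=O)(=O)c2cccc(Cl)c2)cc1)c1ccc(F)cc1` — 1 nM

Of the compounds shown here, two have been measured. In an assay on MDA-MB-231 cells for binding affinity to C-X-C chemokine receptor type 4 (Homo sapiens), read by fluorescence and microscopy, with stated times of 10 min and 30 min (on this read-out higher numbers stand for an effect only at larger amounts of compound and lower numbers for an effect already at smaller amounts), compound 1 gives 1 nM. In this assay compound 2 gives 1 nM. Compound 2 thus stands level with compound 1 at the digits shown, with no difference between the two beyond the usual scatter of the measurement, so the pair gives no measured step from which the weight of any structural change could be read.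

Compound 3 `O=C(NCc1ccc(CNS(=O)(=O)c2cccnc2)cc1)c1ccc(F)cc1` has not yet been measured. It differs from compound 2 in one place: pyridin-3-yl in place of 3-chlorophenyl on a sulfonyl sulfur. For the measured compounds named here, with no measured step touching this part of the shared core, the author expects a small step in this assay at most, if anything towards a somewhat weaker effect, and possibly none beyond the scatter. For compound 3 the estimated result is 2 nM, with a range from 0.5 nM to 8 nM. The change this estimate implies from compound 2 is expected to be a 2.0-fold higher number from compound 2 to compound 3 (0.30 log units; within the scatter).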

Compound 3, effective concentration (reported as EC, without a stated level of effect): 1000 nM
Compound 3: the middle estimate sits 500-fold (2.70 log units) below what was measured; the measured number lies above the stated range.
By their numbers in this assay, from the lowest: compounds 1 and 2 (each within the scatter of the next); then compound 3.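

This result shows that the group on the sulfonyl sulfur is far from indifferent. In this assay, for the compounds shown here, pyridin-3-yl in place of 3-chlorophenyl brings a large change (a 1000-fold higher number from compound 2 to compound 3 (3.00 log units; beyond the scatter)), whereas the earlier compounds offered no measured step from which the weight of any part could be read. The exchange removes the chlorine and brings a ring nitrogen, counted as one hydrogen-bond acceptor, into the six-membered aromatic ring, but no measured evidence explains the size of this step.

From the compounds shown here alone, the two parts of the exchange cannot be separated, so it remains open whether a plain phenyl group on the sulfonyl sulfur would stand with compound 2 or with compound 3. Also open, going by these compounds, is whether a pyridine ring carrying chlorine would regain the lower number of compound 2.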